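Methyl on the ring nitrogen of compound 1

A few compounds are considered here, and "the series" means these few. Any claim that something is new, unique, unknown or untested is made for them only; others in the source may bear on it.

Compound 1 `COc1cccc(CNC(=O)c2c[nH]c3cc(-c4cn[nH]c4)ccc23)c1` is tested in an assay on isolated protein for inhibition of Rho-associated protein kinase 1 (Homo sapiens) (on this read-out higher numbers stand for weaker inhibition and lower numbers for stronger inhibition), where compound 1 reaches the assay's lower limit of < 1 nM; this is a limit, not a number, and compound 1 is the one of the three at the limit of < 1 nM in this assay, at which 1 of the 3 values shown sits. Compound 2 `COc1cccc(CN(C)C(=O)c2c[nH]c3cc(-c4cn[nH]c4)ccc23)c1` gives 19 nM in this assay, and compound 3 `COc1cccc(CN(C(=O)c2cc3ccc(-c4cn[nH]c4)nc3[nH]2)C2CC2)c1` gives 33 nM in this assay. Compound 4 `COc1cccc(CNC(=O)c2cn(C)c3cc(-c4cn[nH]c4)ccc23)c1` is not yet measured; it differs from compound 1 by methyl in place of hydrogen on an aromatic nitrogen. For the measured compounds named here, the only measured step of the same kind, a methyl replacing a hydrogen, is an at least 19-fold higher number from compound 1 to compound 2 (1.27 log units; beyond the scatter), although there the methyl sits on an amide-type nitrogen rather than on the aromatic nitrogen of the fused ring. Taking that step as the nearest guide, a loss of inhibition in this assay is expected for compound 4, with the estimated step being an at least 30-fold higher number from compound 1 to compound 4 (1.47 log units; beyond the scatter). Compound 4 is therefore estimated at 30 nM in this assay, within a range from 3 nM to 300 nM.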

Compound 4, half-maximal inhibitory concentration: < 1 nM
Compound 4 gave a limit, no number (the forecaster's own chance of this, stated with the estimate: 5%); at least 30-fold (1.47 log units) between middle value and limit.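

Compound 1 and compound 4 both give a limit rather than a number, so no step can be read between them: the limit of < 1 nM in this assay, at which 2 of the 4 values shown sit. The compounds shown leave open whether, and by how much, methyl in place of hydrogen on the aromatic nitrogen changes inhibition.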